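The source may report more compounds than this note shows. Statements on the series, on what has been measured and on what is new or still open speak of the compounds shown alone.

Values in a physicochemical assay for solubility, using the shake flask method, in simulated intestinal fluid, measured as kinetic solubility, with a stated time of 20 h, at pH 6.5; on this read-out higher numbers stand for higher solubility and lower numbers for lower solubility:

- Compound 1 `FC(F)(F)c1ccc(Nc2cc3[nH]c(-c4cccc(C(F)(F)F)c4)nc3cn2)nc1`: >= 50000 nM
- Compound 2 `FC(F)(F)c1ccc(Nc2cc3[nH]c(C4CCOCC4)nc3cn2)nc1`: 168000 nM

The entry for compound 1 is a limit and not a number, (the limit of >= 50000 nM in this assay, at which 1 of the 2 values shown sits). Among the measured compounds shown here, that leaves compound 2 with the only true number, 168000 nM.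

Compound 3 `FC(F)(F)c1ccc(Nc2cc3[nH]c(CC4CC4)nc3cn2)nc1` is the next to consider, and it carries this change: cyclopropylmethyl in place of oxan-4-yl on an aromatic carbon. For the measured compounds named here, the one measured step that bears on it, a step that the limit leaves unreadable from compound 1 to compound 2, offers no size to scale from. Starting from compound 2 at 168000 nM, only a slight downward drift is expected, staying within the usual scatter. The expected change is a 1.7-fold lower number from compound 2 to compound 3 (0.23 log units; within the scatter). For compound 3 the estimated value is 100000 nM, with an expected range of 30000 nM to 220000 nM.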

Compound 3, solubility: 156000 nM
Compound 3: middle estimate off by 1.6-fold (0.19 log units), on the low side, and the stated range covers the measured number.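

Putting cyclopropylmethyl in place of oxan-4-yl on this aromatic carbon gives, in this assay, a 1.1-fold lower number from compound 2 to compound 3 (0.03 log units; within the scatter). Across this pair, then, the oxygen-containing six-membered ring and the all-carbon three-membered ring with its extra carbon link give values that cannot be told apart, even though only the oxan-4-yl carries a hydrogen-bond acceptor. The steps from compound 1 cannot be read: the limit of >= 50000 nM in this assay, at which 1 of the 3 values shown sits.

On these data alone, whether an amine or a carboxylic acid at this place would move the number beyond the scatter remains open. So does the effect of a longer carbon chain.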